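The source may report more compounds than this note shows. Statements on the series, on what has been measured and on what is new or still open speak of the compounds shown alone.

Of the compounds shown here, three built on one shared core have been tested so far. Compound 1 `N#CCCCc1c[nH]c2ccc(C(=O)O)cc12` is reported as "not active" (no number reported) in an assay on isolated protein (urine) for inhibition of Myeloperoxidase (Homo sapiens), with a stated time of 5 min (a higher number here means a weaker inhibitor, a lower number a stronger inhibitor), so it contributes no number. Compound 2 `NC(=O)CCCCc1c[nH]c2ccc(F)cc12` gives 39 nM in this assay. Compound 3 `NCCCc1c[nH]c2c(F)cccc12` gives 24 nM in this assay. Of the two numbers, compound 2 holds the higher one, but its gap to compound 3 sits within the scatter of this assay, so no ordering between compound 2 and compound 3 can be read from them.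

Compound 4 `CNC(=O)CCCc1c[nH]c2ccc(F)cc12` has not been measured. It differs from compound 2 in this way: methylcarbamoyl in place of carbamoylmethyl on a saturated chain carbon, three bonds along the chain from an aromatic carbon. The two share every atom; only the joining of the amide along the chain changes. Among the measured compounds shown here, no pair among the measured compounds shows a change of this kind, so there is no step to lean on. The change is expected to be small: a 1.2-fold higher number from compound 2 to compound 4 (0.06 log units; within the scatter) is estimated to stay within the scatter. Compound 4 is therefore expected to give 45 nM in this assay, with a range from 15 nM to 150 nM.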

Compound 4, half-maximal inhibitory concentration: 40 nM
Compound 4: middle estimate off by 1.1-fold (0.05 log units), on the high side, and the stated range covers the measured number.
By their numbers in this assay, from the lowest: compounds 3, 2 and 4 (each within the scatter of the next).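

Moving the amide along the chain, with methylcarbamoyl in place of carbamoylmethyl on a saturated chain carbon, three bonds along the chain from an aromatic carbon, gives in this assay a 1.0-fold higher number from compound 2 to compound 4 (0.01 log units; within the scatter). Among the compounds shown here, at this place, then, the two arrangements of the same atoms cannot be told apart in this assay, something no earlier pair of compounds could show. Nothing available gives a reason for this result.

On these data alone, it remains open how much of the amide this place on the chain needs. An ester or a sulfonamide in the same place on the same core would show whether other groups also fit here, or whether this freedom extends only to rearranging the amide itself.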